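The source may report more compounds than this note shows. Statements on the series, on what has been measured and on what is new or still open speak of the compounds shown alone.

In a functional assay on DU-145 cells (Homo sapiens) for inhibition, read by trypan blue exclusion, with a stated time of 96 h (on this read-out higher numbers stand for weaker inhibition of growth and lower numbers for stronger inhibition of growth), compound 1 (`CN(C)c1ccc(/C=C(/SCc2ccc(Cl)cc2)C(=O)c2ccc(C(=O)O)cc2)cc1`) gives 1000 nM. Compound 2 (`O=C(O)c1ccc(C(=O)/C(=C\c2ccc(Br)c([N+](=O)[O-])c2)SCc2ccc(F)cc2)cc1`) gives 1000 nM, level with compound 1 and within the usual scatter of it. Compound 3 (`CN(C)c1ccc(/C=C(/SCc2ccc(F)cc2)C(=O)c2ccc(C(=O)O)cc2)cc1`) has not yet been measured. It differs from compound 2 in one place: 4-(dimethylamino)phenyl in place of 4-bromo-3-nitrophenyl on a double-bonded chain carbon bound to a double-bonded chain carbon. Here, 4-(dimethylamino)phenyl stands in place of 4-bromo-3-nitrophenyl on a double-bonded chain carbon bound to a double-bonded chain carbon. Among the compounds with values here, no measured pair isolates this change in this assay. Compound 2 gives 1000 nM, and compound 1, which also carries 4-(dimethylamino)phenyl, gives 1000 nM, so no shift beyond the scatter is expected in either direction. The expected change is no change at the digits printed from compound 2 to compound 3 (within the scatter). For compound 3 the estimated value is 1000 nM, with an expected range of 400 nM to 2500 nM.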

Compound 3, concentration for 50% growth inhibition: 10000 nM
Compound 3: the middle estimate sits 10-fold (1.00 log units) below what was measured; the whole stated range lies below it.
By their numbers in this assay, from the lowest: compounds 1 and 2 (each within the scatter of the next); then compound 3.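

In this assay, the change at the double-bonded chain carbon proves to matter: 4-(dimethylamino)phenyl in place of 4-bromo-3-nitrophenyl gives a 10-fold higher number from compound 2 to compound 3 (1.00 log units; beyond the scatter). Within the data shown here, the halogen on the aromatic carbon matters as well, since fluoro in place of chloro, with 4-(dimethylamino)phenyl held constant, gives a 10-fold higher number from compound 1 to compound 3 (1.00 log units; beyond the scatter); the earlier compounds, which differ in two places, could isolate neither change. Nothing available here explains either step.

Still open, from the compounds shown here alone, is whether fluoro in place of chloro would give a step of similar size with 4-bromo-3-nitrophenyl on the chain carbon. Going by these compounds, it is also open how a methoxy group on that aromatic carbon, or an unsubstituted phenyl on the chain carbon, would read in this assay.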